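The source may hold more compounds than are shown below. What is called first, only, known or untested is meant among the compounds shown, and "the series" means these compounds.

Measured in a physicochemical assay for lipophilicity, at pH 7.4; a higher number here means a more lipophilic compound, a lower number a more polar compound:

- compound 1 `Nc1nc(-n2cc(C(=O)O)c(=O)c3cc(F)c([C@H]4C[C@H](O)C4)c(Cl)c32)c(F)cc1F`: 0.3
- compound 2 `Nc1nc(-n2cc(C(=O)O)c(=O)c3cc(F)c([C@H]4C[C@@H](O)C4)c(Cl)c32)c(F)cc1F`: 0.3

Compound 1 and compound 2 stand level in this assay, with compound 2 at 0.3. Within the data shown here, the only measured step is no change at the digits printed from compound 1 to compound 2 (within the scatter). It gives little guidance for what comes next because of the fact that compounds 1 and 2 differ only in the configuration as drawn. The next compound changes its atoms and not just their arrangement in space.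

In compound 3 `Nc1nc(-n2cc(C(=O)O)c(=O)c3cc(F)c(N4CC(N)C4)c(Cl)c32)c(F)cc1F`, 3-aminoazetidin-1-yl stands in place of 3-hydroxycyclobutyl on an aromatic carbon of the shared core: 3-aminoazetidin-1-yl in place of 3-hydroxycyclobutyl on an aromatic carbon. The entering group brings nitrogen into the ring and swaps the hydroxy oxygen for a second nitrogen. Among the measured compounds shown here, no measured pair tests this swap, so the expectation rests on the structural change and on the starting point of compound 2 at 0.3.

A clear move towards the lower, more polar end of this assay is expected, beyond the usual scatter, though its size is uncertain. The expected step is a number 0.90 log units lower from compound 2 to compound 3 (beyond the scatter). For compound 3 the estimate is -0.6, with an expected range from -1.3 to 0.1.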

Compound 3, distribution coefficient: -0.3
The estimate for compound 3 lay 0.30 log units below the measured number; measured number inside the range.
By their numbers in this assay, from the lowest: compound 3; then compounds 1 and 2 (each within the scatter of the next).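

In this assay, placing 3-aminoazetidin-1-yl on this aromatic carbon in place of 3-hydroxycyclobutyl gives a number 0.60 log units lower from compound 2 to compound 3 (beyond the scatter), and the same replacement also gives a number 0.60 log units lower from compound 1 to compound 3 (beyond the scatter). The earlier pair showed only that inverting the stereocentres of the 3-hydroxycyclobutyl group left the reading level, whereas this result shows that the reading does respond at this position when the atoms change, even though both groups have 5 heavy atoms and a four-membered ring. The two steps are a single finding seen from two starting points, not independent confirmation of the replacement, because of a simple structural relationship: the fact that compounds 1 and 2 differ only in the configuration as drawn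

The replacement alters two things at once, a ring carbon becoming nitrogen and the hydroxy group giving way to an amine, so the compounds shown do not tell how much of the step belongs to each change. A 3-hydroxyazetidin-1-yl group or a 3-aminocyclobutyl group on the same aromatic carbon would separate the two changes.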